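From ethyl to fluoro-methoxyphenyl on a ring amide nitrogen

The compounds below may be only part of what the source reports. "The series", "measured", "known", "first", "only" and "open" are said of these compounds alone.

Compound 1 `COc1ccccc1N1C(=O)CSC1C(=O)NCCCCc1ccccc1`: 0%
Compound 2 `CCN1C(=O)CSC1c1cccc(C(=O)NCCCCc2ccccc2)c1`: 0%
Compound 3 `COc1cc(F)ccc1N1C(=O)CSC1c1cccc(C(=O)NCCCCc2ccccc2)c1`: 94%

Of the compounds shown here, three have been measured in a functional assay on HOS-TE85 cells (Homo sapiens) for inhibition, read by CCK-8 assay, with a stated time of 72 h, tested at 1 uM; on this read-out lower numbers stand for less inhibition and higher numbers for more inhibition at the one concentration tested (going by the name of the read-out). Compound 2 shows 0% there, level with compound 1 at the digits reported, and the two together stand lowest of the three. Among the compounds with values here, the only compound with a clear signal is compound 3, which gives 94%.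

The unmeasured compound 4 `COc1c(F)cccc1N1C(=O)CSC1c1cccc(C(=O)NCCCCc2ccccc2)c1` differs from compound 2 in one place: 3-fluoro-2-methoxyphenyl in place of ethyl on an amide-type nitrogen in a ring. Within the data shown here, the one measured step that speaks to this change is the neighbouring one, where a number 94 percentage points higher from compound 2 to compound 3 (beyond the scatter); compound 3 and compound 4 differ only in where the fluorine sits on the entering ring. Compound 1, which carries a methoxyphenyl on the same nitrogen but in a different core, gives no signal, so the aryl group alone does not decide the outcome. Among the measured compounds shown here, still, the closest precedent is large and upward, and compound 4 is therefore expected to move well beyond the scatter in the same direction, an estimated a number 75 percentage points higher from compound 2 to compound 4 (beyond the scatter). For compound 4 the expected read-out is 75%, with a range from 30% to 97%.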

Compound 4, a percentage reported as inhibition, at one concentration (the size of the read-out at that concentration, not a potency): 12%
Compound 4: the middle estimate sits 63 percentage points above what was measured; measured number outside the range, below it.
By their numbers in this assay, from the lowest: compounds 1 and 2 (each within the scatter of the next); then compound 4; then compound 3.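

In this assay, the aryl group on the amide-type nitrogen in the ring proves not to be enough on its own, as putting 3-fluoro-2-methoxyphenyl in place of ethyl on the shared core gives only a number 12 percentage points higher from compound 2 to compound 4 (beyond the scatter) and so a modest change. Within the data shown here, the sharper finding lies in the fluorine, which the earlier compounds could not show: with the core and the methoxy group unchanged, 3-fluoro-2-methoxyphenyl in place of 4-fluoro-2-methoxyphenyl gives a number 82 percentage points lower from compound 3 to compound 4 (beyond the scatter) and so removes most of the read-out. At this position, then, the outcome depends on where the fluorine sits on the entering ring, and nothing available accounts for that dependence.

The compounds shown leave open whether a 2-methoxyphenyl carrying no fluorine on this nitrogen would read closer to compound 3 or to compound 4. From the compounds shown here alone, it also remains open whether a plain phenyl or a 4-chloro-2-methoxyphenyl would retain the level of compound 3, and whether the gap between compound 3 and compound 4 would persist at other concentrations.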